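A few compounds are considered here, and "the series" means these few. Any claim that something is new, unique, unknown or untested is made for them only; others in the source may bear on it.

Measured compounds and their values:

- compound 1 `N=C(N)NS(=O)(=O)c1ccc(/N=C/c2c(Cl)c3ccccc3oc2=O)cc1` gives 620 nM in an ADME assay on cells (Macrophage, Homo sapiens) for cytotoxicity, read by microscopy and CCK-8 assay, with a stated time of 48 h; a higher number here means that more compound is tolerated, a lower number that less compound is tolerated
- compound 2 `CC(C)(C)c1cc(C(C)(C)C)c2oc(=O)c(/C=N/c3ccc(S(N)(=O)=O)cc3)c(Cl)c2c1` gives 580 nM in this assay

Both measurements address how much compound the cells tolerate before damage appears. Compound 2 and compound 1 sit within the usual scatter of each other, so neither can be set apart from the other on these two numbers; the shared core tolerates the two different substitution patterns on its benzene ring without a visible effect in this assay.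

Compound 3 `Cc1cc(C)nc(NS(=O)(=O)c2ccc(/N=C/c3c(Cl)c4cc(C(C)(C)C)cc(C(C)(C)C)c4oc3=O)cc2)n1` has not yet been measured. It differs from compound 2 in one place: 4,6-dimethylpyrimidin-2-yl in place of hydrogen on a sulfonamide nitrogen. Among the compounds with values here, no step between measured compounds touches this position, so nothing measured here tells how the sulfonamide nitrogen responds to substitution. The change is expected to keep compound 3 close to compound 2, with the step of a 1.0-fold higher number from compound 2 to compound 3 (0.01 log units; within the scatter) expected to stay within the scatter, in no particular direction. For compound 3 the value in this assay is estimated at 600 nM, with a range from 250 nM to 1500 nM.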

Compound 3, minimum cytotoxic concentration: 730 nM
Compound 3: middle estimate off by 1.2-fold (0.09 log units), on the low side; measured number inside the range.
By their numbers in this assay, from the lowest: compounds 2, 1 and 3 (each within the scatter of the next).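

Until now, nothing measured showed how the sulfonamide nitrogen responds to substitution. In this assay, within the data shown here, the first step at this position, which puts 4,6-dimethylpyrimidin-2-yl in place of hydrogen on that nitrogen, reads a 1.3-fold higher number from compound 2 to compound 3 (0.10 log units; within the scatter), so this position can carry a group of 8 heavy atoms, including a six-membered aromatic ring with 2 hetero atoms, with no difference that can be told apart from the ordinary spread of repeated measurements. Nothing measured here accounts for this outcome, so the result stands as an observation without an explanation.

This single step describes one group on one shared core, so it does not establish that the sulfonamide nitrogen tolerates substitution in general, and compound 1 cannot extend the comparison since it differs from compound 3 in more than one place. As far as these compounds go, whether a simple methyl group, an acetyl group, a longer alkyl chain, or a chain ending in a carboxylic acid or an amine on this nitrogen would also leave the cells' tolerance within that spread remains open.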